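This account rests on a few compounds, and the source may have more. Where it says the series, first, only, none or still open, it means among the compounds named here.

The measured compounds and their values:

Compound 1 `COc1ccc(Oc2ccccc2-c2ccsc2S(=O)(=O)N2CCN(C(=S)Nc3ccc([N+](=O)[O-])cc3)CC2)cc1OC`: in a functional assay on HL-60 cells (Homo sapiens) for inhibition, read by CCK-8 assay, with a stated time of 48 h (on this read-out higher numbers stand for weaker inhibition and lower numbers for stronger inhibition), compound 1 gives > 50000 nM, which is a limit of the assay and not a number.
Compound 2 `COc1ccc(Oc2ccc([N+](=O)[O-])cc2-c2ccsc2S(=O)(=O)N2CCN(C(=S)Nc3ccc(Cl)cc3)CC2)cc1OC`: in this assay compound 2 gives > 50000 nM, again a limit.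
Compound 3 `COc1ccc(Oc2ccccc2-c2ccsc2S(=O)(=O)N2CCN(C(=O)Nc3ccc(F)cc3)CC2)cc1OC`: in this assay compound 3 gives > 20000 nM, also a limit.

Compound 3 therefore stands at a limit, as do the other two measured compounds; one value sits at the limit of > 20000 nM in this assay, at which 1 of the 3 values shown sits, and two sit at the limit of > 50000 nM in this assay, at which 2 of the 3 values shown sit. Among the compounds with values here, the only measured step that touches compound 3 is a step that the two limits leave unreadable from compound 1 to compound 3, and its size cannot be read from two limits.

Compound 4 `COc1ccc(Oc2ccccc2-c2ccsc2S(=O)(=O)N2CCN(C(=S)Nc3ccc(Cl)cc3)CC2)cc1OC` differs from compound 3 by a group of 10 heavy atoms (7 carbon, 1 nitrogen, 1 sulfur, 1 chlorine; one six-membered aromatic ring of carbon only) in place of a group of 10 heavy atoms (7 carbon, 1 nitrogen, 1 oxygen, 1 fluorine; one six-membered aromatic ring of carbon only), on an amine nitrogen in a ring. Within the data shown here, no measured step bears on this change in a readable way. Compound 2, which carries the same entering group on the same ring nitrogen but differs elsewhere, also gives only a limit, and compound 1, with a different group on that nitrogen, gives only a limit as well.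

On this basis compound 4 is expected to show no inhibition beyond the scatter in this assay and most likely to return a limit again; the estimate for compound 4 is 50000 nM, within 15000 nM to 200000 nM. The step this estimate implies, a step that the limit leaves unreadable from compound 3 to compound 4, is expected to be unreadable against the limit of compound 3.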

Compound 4, half-maximal inhibitory concentration: > 50000 nM
Compound 4: no number, only a limit; the forecaster's own chance of this, stated with the estimate: 85%; the middle value lies on the limit itself.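

In this assay compound 4 gives > 50000 nM, a limit of the assay and not a number. Compound 1, compound 2 and compound 3 also give only limits, so none of the steps to compound 4 can be read. The compounds shown leave open how strongly any of them inhibits, and whether any of these changes of group alters that.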